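Swapping the sulfonyl for a pivaloylamino on compound 1

The source may hold more compounds than are shown below. What is called first, only, known or untested is meant among the compounds shown, and "the series" means these compounds.

For the measured compounds named here, compound 1 `C=CC(=O)Nc1cc(Nc2ncc(Cl)c(Nc3ccccc3S(=O)(=O)C(C)C)n2)c(OC)cc1N1CCN(C)CC1` holds the only numeric value in the set: in a functional assay on NCI-H1975 cells (Homo sapiens) for inhibition, read by CellTiter-Glo, with a stated time of 72 h (on this read-out higher numbers stand for weaker inhibition of growth and lower numbers for stronger inhibition of growth), compound 1 gives 43 nM. Compound 2 `C=CC(=O)Nc1cc(Nc2ncc(Cl)c(NC3CC3)n2)c(OC)cc1N1CCN(C)CC1` reaches only a limit of the assay; in this assay compound 2 gives > 10000 nM, which is a limit and not a number (the limit of > 10000 nM in this assay, at which 1 of the 2 values shown sits). The step of an at least 230-fold higher number from compound 1 to compound 2 (2.36 log units; beyond the scatter) shows that exchanging the whole 2-(isopropylsulfonyl)phenyl for cyclopropyl loses activity well beyond the scatter. Compound 3 `C=CC(=O)Nc1cc(Nc2ncc(Cl)c(Nc3ccccc3NC(=O)C(C)(C)C)n2)c(OC)cc1N1CCN(C)CC1` keeps that phenyl and changes only its substituent: ((tert-butyl)carbonyl)amino in place of isopropylsulfonyl on an aromatic carbon. Going by the values given here, the one measured step bears on this only indirectly, as it removes the ring entirely while compound 3 retains it. A loss smaller than the measured one is therefore expected, but its size rests on no direct comparison. Compound 3 is expected at 300 nM, in the range 60 nM to 2000 nM, an expected step of a 7.0-fold higher number from compound 1 to compound 3 (0.84 log units; beyond the scatter).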

Compound 3, concentration for 50% growth inhibition: 950 nM
Compound 3: the middle estimate sits 3.2-fold (0.50 log units) below what was measured; the range from low to high includes it.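

With the phenyl kept, the substituent alone still matters in this assay: exchanging isopropylsulfonyl for ((tert-butyl)carbonyl)amino on this aromatic carbon gives a 22-fold higher number from compound 1 to compound 3 (1.34 log units; beyond the scatter). The earlier step changed the ring and its substituent together, whereas this one shows that a large loss needs no removal of the ring. Nothing at hand gives a cause for this loss.

Still open, from the compounds shown here alone, is which part of the exchange counts, since the entering group differs from the leaving one at once in its linking atom, its atom count and its hydrogen-bond donor. Methylsulfonyl, dimethylaminosulfonyl and acetylamino on the same aromatic carbon would help to separate these differences, and would show whether the sulfonyl itself or only the size of the group tracks with the read-out.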